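Swapping cyano for isopropyl on the shared core

This account rests on a few compounds, and the source may have more. Where it says the series, first, only, none or still open, it means among the compounds named here.

In a functional assay on MT2 cells (Homo sapiens) for cytotoxicity (a lower number here means that less compound is tolerated, a higher number that more compound is tolerated), compound 1 `CC(C)=CCOc1cc(Nc2nccs2)ccc1C` gives 17000 nM. Among the compounds with values here, compound 2 `CC(C)=CCOc1cc(Nc2nccs2)ccc1C#N` gives 500 nM, the lower of the two numbers so far, which means less of it is tolerated. Within the data shown here, the only measured step is a 34-fold lower number from compound 1 to compound 2 (1.53 log units; beyond the scatter), a large change that comes from cyano in place of methyl on an aromatic carbon.

Compound 3 `CC(C)=CCOc1cc(Nc2nccs2)ccc1C(C)C` keeps the same core but carries isopropyl in place of cyano on an aromatic carbon. That step removes the same cyano group, and the incoming group is closer in kind to the methyl of compound 1, which gives 17000 nM. A large upward move in this assay is therefore expected, roughly undoing the earlier step. Among the measured compounds shown here, no measured compound carries isopropyl yet, so this rests on a single comparison and the range must stay wide. The estimated change is a 24-fold higher number from compound 2 to compound 3 (1.38 log units; beyond the scatter). For compound 3 the expected value is 12000 nM, with an estimated range from 3000 nM to 40000 nM.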

Compound 3, half-maximal cytotoxic concentration: 31000 nM
The estimate for compound 3 lay 2.6-fold (0.41 log units) below the measured number, within the range that was stated.
By their numbers in this assay, from the lowest: compound 2; then compounds 1 and 3 (each within the scatter of the next).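

On the aromatic carbon para to the (1,3-thiazol-2-yl)amino group, replacing cyano with isopropyl in this assay gives a 62-fold higher number from compound 2 to compound 3 (1.79 log units; beyond the scatter), a step as large as the earlier drop and in the opposite direction. Moving from methyl to a larger carbon group gives a 1.8-fold higher number from compound 1 to compound 3 (0.26 log units; within the scatter) and stays within the scatter, so these two compounds cannot be told apart here, and of the three groups tested at this position only cyano stands apart, with much less compound tolerated. No measurement shown here accounts for why cyano differs from methyl and isopropyl.

On these data alone, whether an amine, a carboxylic acid or a longer alkyl chain on this carbon would behave like cyano or like methyl and isopropyl remains open. Also open, as far as these compounds go, is whether the contrast between cyano and isopropyl would survive if another group replaced the (3-methylbut-2-en-1-yl)oxy group, since all three compounds carry that same group.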